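Chloro for fluoro on two different cores

The source may report more compounds than this note shows. Statements on the series, on what has been measured and on what is new or still open speak of the compounds shown alone.

Compound 1 `O=S(=O)(/C=C/c1ncccc1F)c1cccc(Cl)c1` and compound 2 `O=S(=O)(/C=C/c1ncccc1Cl)c1cccc(Cl)c1` share one core and differ in a single place. In an assay on U2OS cells for activation of nuclear factor erythroid 2-related factor 2 (Homo sapiens), read by beta-arrestin recruitment, with a stated time of 6 h (a lower number here means that less compound is needed, a higher number that more compound is needed for the effect), compound 1 gives 198 nM, while compound 2 gives 46 nM. The change is chloro in place of fluoro on an aromatic carbon, and it made a step of a 4.3-fold lower number from compound 1 to compound 2 (0.63 log units; beyond the scatter).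

Compound 3 `O=S(=O)(/C=C/c1cccnc1)c1ccccc1F` is built on another core; the difference between the two cores is not broken down here. In this assay compound 3 gives 6860 nM, the highest number among the three measured compounds, beyond the scatter from both others.

Compound 4 `O=S(=O)(/C=C/c1cccnc1)c1ccccc1Cl` is not yet measured. It differs from compound 3 by chloro in place of fluoro on an aromatic carbon. This is the same kind of change as that between compound 1 and compound 2, not the same change: there the place is on a six-membered aromatic ring with 1 nitrogen, two atoms from the ring nitrogen; here it is on a six-membered aromatic ring of carbon only, though in both cases ortho to a large group. This change has been measured once only, on the other core, so its size is not certain to carry over.

Going by the values given here, the expectation for compound 4 in this assay rests on compound 1 and compound 2, whose step a 4.3-fold lower number from compound 1 to compound 2 (0.63 log units; beyond the scatter) is the only measured instance. A somewhat smaller step from compound 3 to compound 4 is expected, namely a 2.7-fold lower number from compound 3 to compound 4 (0.44 log units; beyond the scatter), since the core is different. Compound 4 is estimated at 2500 nM, expected to fall between 1000 nM and 6000 nM.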

Compound 4, half-maximal effective concentration: 2850 nM
Beside the measured number, compound 4's estimate is 1.1-fold (0.06 log units) below it; measured number inside the range.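

In this assay, chloro in place of fluoro on an aromatic carbon again lowers the number on the second core, with a step of a 2.4-fold lower number from compound 3 to compound 4 (0.38 log units; beyond the scatter). The two steps run in the same direction, and the gap between them does not exceed what repeated measurements would allow: the same change on two cores in this assay, a 4.3-fold lower number (0.63 log units; beyond the scatter) from compound 1 to compound 2 and a 2.4-fold lower number (0.38 log units; beyond the scatter) from compound 3 to compound 4, 1.8-fold (0.25 log units) apart, within the scatter of two such steps

This supports carrying the change between these two cores, in direction and roughly in size, even though the changed place lies on a different kind of ring in each pair, but it rests on two pairs only. It does not show that the step is constant, since a real difference of this size could not be told from scatter, and it says nothing about a third core or about why chloro gives the lower number.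

The compounds shown leave open how bromo, methyl or methoxy in the same place would compare with fluoro and chloro on either core. They also leave open whether the step would persist if the chloro on the other aromatic ring of compound 1 and compound 2 were replaced by a group such as an amine or a carboxylic acid.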